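Lengthening the Amide Side Chain: Compound 2 to Compound 3

The compounds below may be only part of what the source reports. "The series", "measured", "known", "first", "only" and "open" are said of these compounds alone.

In an assay on membranes from brain for antagonist activity at adenosine receptor A1 (Rattus norvegicus) (on this read-out higher numbers stand for weaker inhibition and lower numbers for stronger inhibition), compound 1 `CCCn1c(=O)c2nc(-c3ccc(OCC(=O)OCC)cc3O)[nH]c2n(CCC)c1=O` gives 31 nM, while compound 2 `CCCn1c(=O)c2nc(-c3ccc(OCC(N)=O)cc3O)[nH]c2n(CCC)c1=O` gives 6.5 nM, the lowest of the two numbers. Within the data shown here, the only measured step, a 4.8-fold lower number from compound 1 to compound 2 (0.68 log units; beyond the scatter), concerns the carbonyl side of the amide. Compound 3 `CCCn1c(=O)c2nc(-c3ccc(OCC(=O)NCCN)cc3O)[nH]c2n(CCC)c1=O` differs from compound 2 by 2-aminoethyl in place of hydrogen on an amide-type nitrogen. Among the measured compounds shown here, no measured step addresses a change on the amide nitrogen, so no firm direction can be read from the data, and only a small shift, if any, is expected: a 1.4-fold higher number from compound 2 to compound 3 (0.14 log units; within the scatter). Compound 3 is therefore estimated at 9 nM, within a range of 3 nM to 27 nM.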

Compound 3, antagonist equilibrium constant in the adenosine receptor A1 assay: 2.4 nM
The estimate for compound 3 lay 3.8-fold (0.57 log units) above the measured number; measured number below the stated range.
By their numbers in the adenosine receptor A1 assay, from the lowest: compound 3; then compound 2; then compound 1.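

In the adenosine receptor A1 assay, the amide nitrogen proves to be a place where a substituent is not merely tolerated: 2-aminoethyl in place of hydrogen gives a 2.7-fold lower number from compound 2 to compound 3 (0.43 log units; beyond the scatter). Measured against the ester, the full change to (2-aminoethyl)amino on the carbonyl carbon gives a 13-fold lower number from compound 1 to compound 3 (1.11 log units; beyond the scatter). In a physicochemical assay for solubility, in the presence of a further agent that is not named here (a lower number here means a less soluble compound, a higher number a more soluble compound), compound 2 gives 5600000 nM and compound 3 gives 710000 nM. The gain comes with a cost in the physicochemical assay: the measured solubility of compound 2, 5600000 nM, and of compound 3, 710000 nM, a 7.9-fold lower number (0.90 log units; beyond the scatter)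

As far as these compounds go, whether the amine of the 2-aminoethyl group matters, or the added chain alone, remains open. An ethyl group on the same nitrogen would separate the two, and a longer chain such as 3-aminopropyl would test the chain length.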